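Two weak aryl ureas and an untested methylsulfanyl analogue

A few compounds are considered here, and "the series" means these few. Any claim that something is new, unique, unknown or untested is made for them only; others in the source may bear on it.

Measured compounds:
compound 1 `O=C(Nc1ccccc1Br)N[C@H]1CC[C@H](Oc2ccc(F)cc2)CC1` — 7700 nM
compound 2 `O=C(Nc1ccccc1I)N[C@H]1CC[C@H](Oc2ccc(F)cc2)CC1` — > 20000 nM

Both compounds share a core built from a urea linked to a fluorophenoxy-cyclohexyl unit and differ only on the aryl ring attached to the other urea nitrogen. In a functional assay on CRL2813 cells (Homo sapiens) for cytotoxicity, read by sulforhodamine B assay, with a stated time of 5 days (a higher number here means a weaker inhibitor, a lower number a stronger inhibitor), compound 1 gives 7700 nM. Compound 2 reaches only > 20000 nM, which is a limit of the assay rather than a number, and it sits at the limit of > 20000 nM in this assay, at which 1 of the 2 values shown sits. The change of bromo to iodo on the aromatic carbon gives an at least 2.5-fold higher number from compound 1 to compound 2 (0.41 log units; beyond the scatter), so compound 2 is the weaker of the two as far as the numbers show.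

Compound 3 `CSc1cccc(NC(=O)N[C@H]2CC[C@H](Oc3ccc(F)cc3)CC2)c1` has not been measured in this assay. It differs from compound 2 by 3-(methylsulfanyl)phenyl in place of 2-iodophenyl on an amide-type nitrogen. Going by the values given here, no measured step covers this change; the one step that exists concerns only a halogen swap on the same ring and went toward a higher number. With both measured compounds weak, compound 3 is expected to stay in the same weak region, and the step of an at least 1.3-fold lower number from compound 2 to compound 3 (0.12 log units; that floor lies within the scatter) is expected to lie within the scatter. Compound 3 is therefore estimated at 15000 nM, with a range from 5000 nM to 40000 nM.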

Compound 3, half-maximal inhibitory concentration: 11100 nM
Beside the measured number, compound 3's estimate is 1.4-fold (0.13 log units) above it, within the range that was stated.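

Compound 3 shows that an aryl group carrying no halogen, 3-(methylsulfanyl)phenyl, can stand on this amide-type nitrogen and still give a measured number in this assay. Replacing 2-bromophenyl with this group gives a 1.4-fold higher number from compound 1 to compound 3 (0.16 log units; within the scatter), so this change separates the two compounds no more than repeated measurement would, whereas the earlier bromo-to-iodo step went beyond the scatter. Replacing 2-iodophenyl gives an at least 1.8-fold lower number from compound 2 to compound 3 (0.25 log units; that floor lies within the scatter), so the step can be read only as far as that floor, and it does not establish a real difference, as the value of compound 2 is a limit of the assay and not a number: the limit of > 20000 nM in this assay, at which 1 of the 3 values shown sits.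

The compounds shown leave open how much of the number of compound 3 belongs to the sulfur atom and how much to the aryl ring itself, which a plain phenyl, a methoxy or a chloro group on this ring would help to separate. They also leave open whether a more different group here, such as an amine or a carboxylic acid, would move the number out of this weak region at all.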